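Swapping a fluorophenyl for a benzimidazole on the benzyl arm

A few compounds are considered here, and "the series" means these few. Any claim that something is new, unique, unknown or untested is made for them only; others in the source may bear on it.

Compound 1 `CNC(=O)c1cc(C(=O)NC2CC2)cn(Cc2cccc(F)c2)c1=O` is measured in a physicochemical assay for lipophilicity, at pH 7.4 (on this read-out lower numbers stand for lower lipophilicity and higher numbers for higher lipophilicity), at 3.2, the highest of the three numbers. Compound 2 `CNC(=O)c1cc(C(=O)NC)c(=O)n(Cc2ccccc2)c1` gives 2.4, and compound 3 `CNC(=O)c1cc(C(N)=O)cn(Cc2ccccc2)c1=O` gives 2. For the measured compounds named here, the only step between single-point neighbours, a number 0.40 log units lower from compound 2 to compound 3 (beyond the scatter), shows that exchanging a methyl for a hydrogen on an amide nitrogen lowers the read-out modestly. Compound 4 `CNC(=O)c1cc(C(=O)NC2CC2)cn(Cc2ccc3nc[nH]c3c2)c1=O` differs from compound 1 by 1H-benzimidazol-6-yl in place of 3-fluorophenyl on a saturated chain carbon bound to an aromatic nitrogen, which exchanges a group without hydrogen-bond donors or acceptors for one bearing one of each. Going by the values given here, no measured step covers this exact change, and the amide step is only a loose analogy, so the expectation rests mainly on the loss of fluorine and the entry of a more polar, two-ring group. A clear fall is therefore expected, larger than the amide step: a number 1.20 log units lower from compound 1 to compound 4 (beyond the scatter). Compound 4 is estimated at 2, with a likely range from 1.4 to 2.6.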

Compound 4, distribution coefficient: 1.2
The estimate for compound 4 lay 0.80 log units above the measured number, and the stated range ends above it.
By their numbers in this assay, from the lowest: compound 4; then compound 3; then compound 2; then compound 1.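

For the compounds shown here, at the saturated chain carbon bound to an aromatic nitrogen, the read-out of this assay can move a long way: the exchange of 3-fluorophenyl for 1H-benzimidazol-6-yl gives a number 2.00 log units lower from compound 1 to compound 4 (beyond the scatter) and this large step far exceeds the modest amide change, a number 0.40 log units lower from compound 2 to compound 3 (beyond the scatter) on the only earlier step. The entering group has 1 hydrogen-bond donor and 1 hydrogen-bond acceptor, while 3-fluorophenyl has 0 of each, so this single exchange alters several features at once. No supporting measurement explains why the number falls so far.

On these data alone, how much of the step belongs to the loss of fluorine and how much to the entering five-membered ring remains open. Also open, as far as these compounds go, is where an indole or a pyridine at the same place would fall in this assay relative to compound 1 and compound 4.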